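Adding a carboxy group to compound 1

A few compounds are considered here, and "the series" means these few. Any claim that something is new, unique, unknown or untested is made for them only; others in the source may bear on it.

In a functional assay on KB cells (Homo sapiens) for antiproliferative activity (a lower number here means a stronger inhibitor, a higher number a weaker inhibitor), compound 1 `COc1ccc(S(=O)(=O)N2CCc3cccc(Nc4ccccc4)c32)cc1` gives 342 nM and sits level with compound 3 `COc1ccc(S(=O)(=O)N2CCc3cccc(Nc4ccc(F)cc4)c32)cc1` at 557 nM on these numbers, while compound 2 `COc1ccc(Nc2cccc3c2N(S(=O)(=O)c2ccc(OC)cc2)CC3)cc1` at 1200 nM stands apart from both. Still unmeasured is compound 4 `COc1ccc(S(=O)(=O)N2CCc3cccc(Nc4ccc(C(=O)O)cc4)c32)cc1` which differs from compound 1 by a single change: carboxy in place of hydrogen on an aromatic carbon para to a large group.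

Two measured steps swap a hydrogen on an aromatic carbon in a similar way. Fluoro gives a 1.6-fold higher number from compound 1 to compound 3 (0.21 log units; within the scatter) and so stays within the scatter. Methoxy gives a 3.5-fold higher number from compound 1 to compound 2 (0.55 log units; beyond the scatter) which is a modest step beyond it. Putting fluoro in place of methoxy gives a 2.2-fold lower number from compound 2 to compound 3 (0.33 log units; beyond the scatter) which is also modest. Within the data shown here, neither swap on compound 1 brought a lower number beyond the scatter, but no measured compound carries a carboxy group, so any forecast here is loose. The methoxy step a 3.5-fold higher number from compound 1 to compound 2 (0.55 log units; beyond the scatter) is the nearest guide, and a somewhat larger move in the same direction is expected. The estimated change is an 8.8-fold higher number from compound 1 to compound 4 (0.94 log units; beyond the scatter) in this assay toward a weaker inhibitor. For compound 4 the expected value is 3000 nM with an estimated range of 700 nM to 15000 nM around it.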

Compound 4, half-maximal inhibitory concentration: 846 nM
Estimate against measurement, compound 4: 3.5-fold (0.55 log units) above; low and high end bracket the measured number.
By their numbers in this assay, from the lowest: compounds 1, 3, 4 and 2 (each within the scatter of the next, the first and the last beyond it).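

In this assay, putting a carboxy group in place of the hydrogen para to a large group gives a 2.5-fold higher number from compound 1 to compound 4 (0.39 log units; beyond the scatter) and so a modest step toward a weaker inhibitor, the first result at this position for a group with a hydrogen-bond donor. Set against the other two groups at the same carbon, carboxy in place of fluoro gives a 1.5-fold higher number from compound 3 to compound 4 (0.18 log units; within the scatter) and carboxy in place of methoxy gives a 1.4-fold lower number from compound 2 to compound 4 (0.15 log units; within the scatter) and both of these steps lie within the scatter, so compound 4 cannot be placed in any order relative to compound 3 or compound 2. No measurement shown here accounts for what the carboxy group does at this position.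

From the compounds shown here alone, it remains open whether a methyl ester, a primary amide, an amine or a longer chain ending in a carboxylic acid on this same carbon would read closer to compound 1 or further from it. Also open is how a carboxy group would read on the other carbons of this ring, as every substituted compound shown carries its group at this one place.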